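Replacing a Dichlorophenyl Urea End by a Trifluoromethylphenyl One

The source may hold more compounds than are shown below. What is called first, only, known or untested is meant among the compounds shown, and "the series" means these compounds.

Measured so far:
compound 1, `COc1ccc(Cn2ncc3c2NC(=O)CC(c2cccc(NC(=O)Nc4cccc(Cl)c4)c2)=N3)cc1`, 630 nM
compound 2, `COc1ccc(Cn2ncc3c2NC(=O)CC(c2cccc(NC(=O)Nc4ccc(Cl)cc4)c2)=N3)cc1`, 580 nM
compound 3, `COc1ccc(Cn2ncc3c2NC(=O)CC(c2cccc(NC(=O)Nc4ccc(Cl)c(Cl)c4)c2)=N3)cc1`, 14900 nM

In a functional assay on U-937 cells (Homo sapiens) for inhibition, read by MTT assay, with a stated time of 24 h (on this read-out higher numbers stand for weaker inhibition of growth and lower numbers for stronger inhibition of growth), compound 3 gives the highest number of the three, so it inhibits growth least. Compound 4, `COc1ccc(Cn2ncc3c2NC(=O)CC(c2cccc(NC(=O)Nc4ccc(C(F)(F)F)cc4)c2)=N3)cc1`, differs from compound 3 by 4-(trifluoromethyl)phenyl in place of 3,4-dichlorophenyl on an amide-type nitrogen. Going by the values given here, the steps that bear on this are a 24-fold higher number from compound 1 to compound 3 (1.37 log units; beyond the scatter) and a 26-fold higher number from compound 2 to compound 3 (1.41 log units; beyond the scatter): adding a second chloro to a monosubstituted ring weakened inhibition strongly. Compound 4 returns to a ring with a single substituent, so the step is expected to reverse much of that loss, giving an estimated 15-fold lower number from compound 3 to compound 4 (1.17 log units; beyond the scatter). Compound 4 is therefore expected to give about 1000 nM, within the range 300 nM to 5000 nM.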

Compound 4, concentration for 50% growth inhibition: 110 nM
Beside the measured number, compound 4's estimate is 9.1-fold (0.96 log units) above it; measured number below the stated range.
By their numbers in this assay, from the lowest: compound 4; then compounds 2 and 1 (each within the scatter of the next); then compound 3.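

In this assay, 4-(trifluoromethyl)phenyl gives a 140-fold lower number from compound 3 to compound 4 (2.13 log units; beyond the scatter), so this single-substituent ring does more than undo the loss seen with 3,4-dichlorophenyl. It also improves on both single-chloro rings, with a 5.3-fold lower number from compound 2 to compound 4 (0.72 log units; beyond the scatter) and a 5.7-fold lower number from compound 1 to compound 4 (0.76 log units; beyond the scatter), showing that this end of the molecule can give stronger inhibition than those two compounds revealed. Nothing available explains why this change helps.

Still open, going by these compounds, is whether a nitrile or an amine in place of trifluoromethyl on this ring would keep that gain.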